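Swapping chloro for hydroxy on the aromatic ring

This account rests on a few compounds, and the source may have more. Where it says the series, first, only, none or still open, it means among the compounds named here.

Measured so far in an assay on isolated protein for inhibition of Dihydrofolate reductase (Mus musculus), at pH 7.20; on this read-out higher numbers stand for higher potency (the scale is a negative logarithm) and lower numbers for lower potency:
- compound 1 `CC1(C)N=C(N)N=C(N)N1c1ccccc1N` gives 3.41
- compound 2 `CSc1ccccc1N1C(N)=NC(N)=NC1(C)C` gives 2.48
- compound 3 `CC1(C)N=C(N)N=C(N)N1c1ccccc1Cl` gives 4.72

Compound 3 stands highest of the three, with a number 1.31 log units higher from compound 1 to compound 3 (beyond the scatter) and a number 2.24 log units higher from compound 2 to compound 3 (beyond the scatter) separating it from the other two. Compound 4 `CC1(C)N=C(N)N=C(N)N1c1ccccc1O` shares the same core and differs from compound 3 in one place: hydroxy in place of chloro on an aromatic carbon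

Both measured steps bear on this change, since each ends at the chloro compound. Starting from compound 1, a number 1.31 log units higher from compound 1 to compound 3 (beyond the scatter) was seen, and from compound 2, a number 2.24 log units higher from compound 2 to compound 3 (beyond the scatter). The group that enters in compound 4 carries a hydrogen-bond donor and acceptor, as does the amino group of compound 1, so the step is expected to run in the opposite direction to those, downward and beyond the scatter, roughly undoing the rise seen from compound 1. For compound 4 the expected step is a number 1.32 log units lower from compound 3 to compound 4 (beyond the scatter), giving an estimate of 3.4, within a range of 2.6 to 4.2.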

Compound 4, logarithm of the reciprocal of the active concentration, log(1/C): 2.92
Beside the measured number, compound 4's estimate is 0.48 log units above it, within the range that was stated.
By their numbers in this assay, from the lowest: compound 2; then compound 4; then compound 1; then compound 3.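

In this assay hydroxy proves a poor substitute for chloro on this aromatic carbon, with a number 1.80 log units lower from compound 3 to compound 4 (beyond the scatter) and compound 3 still the most potent of the four. Hydroxy also separates from the two remaining groups, with a number 0.49 log units lower from compound 1 to compound 4 (beyond the scatter) when it replaces amino and a number 0.44 log units higher from compound 2 to compound 4 (beyond the scatter) when it replaces methylsulfanyl, so hydroxy and amino, which both carry a hydrogen-bond donor, are not interchangeable here. Nothing available accounts for this order of the four groups.

The compounds shown leave open whether another halogen, such as fluoro or bromo, or a small carbon group such as methyl, would match chloro at this position. Also open, from the compounds shown here alone, is whether methoxy, which keeps the oxygen of hydroxy but not its hydrogen, would land nearer compound 4 or compound 3.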